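Notes on a cyano variant of compound 3

The source may hold more compounds than are shown below. What is called first, only, known or untested is meant among the compounds shown, and "the series" means these compounds.

Measured compounds:
compound 1 `CC1=C(c2cccc(F)c2)C(c2ccc(OC[C@H](C)N3CC[C@@H](C)C3)cc2)Oc2ccc(O)cc21`, 1 nM
compound 2 `CC1=C(c2cccc(O)c2)C(c2ccc(OC[C@H](C)N3CC[C@H](C)C3)cc2)Oc2ccc(O)cc21`, 0.2 nM
compound 3 `CC1=C(c2ccccc2)C(c2ccc(OC[C@H](C)N3CC[C@@H](C)C3)cc2)Oc2ccc(O)cc21`, 0.4 nM

All three were run in a functional assay on MCF7 cells (Homo sapiens) for antiproliferative activity, read by CellTiter-Glo, with a stated time of 5 days; a higher number here means a weaker inhibitor, a lower number a stronger inhibitor. Compound 3 stands second highest of the three numbers. Its nearest neighbour is compound 2, whose value lies within the scatter of that of compound 3, so no order between them can be read. Its furthest neighbour is compound 1; the step of a 2.5-fold lower number from compound 1 to compound 3 (0.40 log units; beyond the scatter) is modest but beyond the scatter.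

Compound 4 `CC1=C(c2ccc(C#N)cc2)C(c2ccc(OC[C@H](C)N3CC[C@@H](C)C3)cc2)Oc2ccc(O)cc21` has not yet been measured in this assay. It differs from compound 3 in one place: cyano in place of hydrogen on an aromatic carbon.

Within the data shown here, only one measured step bears on the pendant phenyl here, the step from compound 1 to compound 3, in which a hydrogen replaced a fluoro. That step points the other way from the present change and involves a different group, so it gives only a weak guide. Compound 2 carries a hydroxyl on that ring but also differs elsewhere, so its value cannot be set against compound 3 as a single step.

On this basis compound 4 is expected to land close to compound 3, with a step of a 1.5-fold higher number from compound 3 to compound 4 (0.18 log units; within the scatter) that may slip a little toward a higher number. The estimate for compound 4 in this assay is 0.6 nM, with a range from 0.2 nM to 2 nM.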

Compound 4, half-maximal inhibitory concentration: 10 nM
Compound 4: the middle estimate sits 17-fold (1.22 log units) below what was measured, and the stated range ends below it.
By their numbers in this assay, from the lowest: compounds 2 and 3 (each within the scatter of the next); then compound 1; then compound 4.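

In this assay, among these compounds, the change from phenyl to 4-cyanophenyl gives a 25-fold higher number from compound 3 to compound 4 (1.40 log units; beyond the scatter) and so shows that this ring position, on an aromatic carbon para to a large group, is far less forgiving than the earlier compounds suggested. Among the compounds shown here, the only earlier single step on this ring, a 2.5-fold lower number from compound 1 to compound 3 (0.40 log units; beyond the scatter) and a modest one, gave no sign of a change this large. Compound 4 also stands apart from the fluoro compound, with a 10-fold higher number from compound 1 to compound 4 (1.00 log units; beyond the scatter) as the measured gap, so a substituent on this ring can cost much more than the 3-fluorophenyl of compound 1 does, though that step changes both the group and its place on the ring; no measurement shown here accounts for the size of the step from hydrogen to cyano.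

As far as these compounds go, it remains open whether the drop belongs to the cyano group itself or to any substituent on this aromatic carbon. A methoxy, a chlorine or an amine at the same place on the ring, set against compound 3, would separate those two readings.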